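Trimming the Distal Carbamate of a Bivalent Melatonin Ligand

A few compounds are considered here, and "the series" means these few. Any claim that something is new, unique, unknown or untested is made for them only; others in the source may bear on it.

Measured so far:
- compound 1, `CC(=O)NCCN(C)c1cccc(OCCCCCCN)c1`: 447 nM
- compound 2, `CC(=O)NCCN(C)c1cccc(OCCCCCCOc2cccc(OC(=O)NC3CCCCC3)c2)c1`: 27.5 nM

In an assay on cells for displacement of a labelled ligand from melatonin receptor type 1A (Homo sapiens), using the Cheng-Prusoff equation, with a stated time of 90 min (on this read-out lower numbers stand for stronger inhibition and higher numbers for weaker inhibition), compound 1 gives 447 nM, while compound 2 gives 27.5 nM. Compound 2 thus holds the lower of the two numbers, and its gap to compound 1 lies well beyond the scatter of repeated measurements, so it is the stronger binder of the pair. The two share the same core and linker chain and differ only in what sits at the far end of that chain.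

Compound 3, `CC(=O)NCCN(C)c1cccc(OCCCCCCOc2cccc(O)c2)c1`, keeps everything in compound 2 except that it carries hydrogen in place of cyclohexylcarbamoyl on an oxygen on an aromatic ring, leaving a free phenol at the distal end. Among the compounds with values here, no pair of measured compounds shows this particular change, so its size can only be estimated. Because compound 2 reaches 27.5 nM with the full carbamate in place, removing that group is expected to weaken binding, and the step from compound 2 to compound 3 is estimated as a 4.0-fold higher number from compound 2 to compound 3 (0.60 log units; beyond the scatter). Compound 3 is therefore expected to give about 110 nM, most likely within 30 nM to 400 nM.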

Compound 3, inhibition constant: 58.9 nM
Compound 3: the middle estimate sits 1.9-fold (0.27 log units) above what was measured, and the stated range covers the measured number.
By their numbers in this assay, from the lowest: compound 2; then compound 3; then compound 1.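

In this assay, taking the cyclohexylcarbamoyl group off the oxygen on the aromatic ring gives a 2.1-fold higher number from compound 2 to compound 3 (0.33 log units; beyond the scatter) and leaves a free phenol at the far end of the chain. This step lies beyond the scatter but is modest, so the full carbamate is not essential for binding in the nanomolar range seen here. The second aromatic ring alone already accounts for the larger of the two new steps: putting 3-hydroxyphenoxy in place of amino on the saturated chain carbon gives a 7.6-fold lower number from compound 1 to compound 3 (0.88 log units; beyond the scatter) and thus retains much of the advantage that the carbamate-bearing end has over the simple amine.

The compounds shown leave open whether the remaining difference between the phenol and the carbamate belongs to the cyclohexyl ring or to the carbamate link itself, a question that a small methylcarbamoyl group or a methyl ether on the same oxygen could help to separate. They also leave open how either end would behave on a shorter or longer chain than the one shared here. Nothing measured here explains the size of either step.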